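This account rests on a few compounds, and the source may have more. Where it says the series, first, only, none or still open, it means among the compounds named here.

Measured so far:
compound 1, `Cc1nc(S(C)(=O)=O)ccc1Oc1ncnc(OC2CCN(C(=O)O[C@@H](C)CF)CC2)c1F`, 84%
compound 2, `Cc1nc(S(C)(=O)=O)ccc1Oc1ncnc(OC2CCN(C(=O)OC3COC3)CC2)c1F`, 66%

Both compounds were tested in a functional assay on isolated protein for inhibition of Glucose-dependent insulinotropic receptor (Rattus norvegicus), read by HTRF and cAMP accumulation; on this read-out higher numbers stand for larger maximal responses and lower numbers for smaller maximal responses. Compound 1 gives 84%, and compound 2 gives 66%, which is the lower of the two numbers: the step of a number 18 percentage points lower from compound 1 to compound 2 (beyond the scatter) lies beyond the usual scatter.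

Compound 3, `Cc1nc(S(C)(=O)=O)ccc1Oc1ncnc(OC2CCN(C(=O)C(C)(C)F)CC2)c1F`, has not yet been measured. Its difference from compound 2 is 1-fluoro-1-methylethyl in place of (oxetan-3-yl)oxy on a carbonyl carbon. Among the compounds with values here, this change touches the same place that the one measured step touched, the group on a carbonyl carbon whose other neighbour is an amide-type nitrogen in a ring. That step, a number 18 percentage points lower from compound 1 to compound 2 (beyond the scatter), went down when an oxetan-3-yl group replaced a 1-(fluoromethyl)ethyl group. Compound 3 removes the oxetane ring again and brings in a fluorine-bearing branched chain, which resembles the group of compound 1 more than that of compound 2. On that single comparison, a rise back toward the level of compound 1 is expected, though the carbonyl now carries a carbon instead of an oxygen, so the comparison is loose. The expected step is a number 12 percentage points higher from compound 2 to compound 3 (beyond the scatter), and compound 3 is estimated to give 78%, within a range from 60% to 95%.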

Compound 3, largest response reached (reported as efficacy), in percent of the reference or control that the assay uses: 74%
Compound 3: middle estimate off by 4 percentage points, on the high side, within the range that was stated.
By their numbers in this assay, from the lowest: compounds 2, 3 and 1 (each within the scatter of the next, the first and the last beyond it).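

In this assay the step of a number 8 percentage points higher from compound 2 to compound 3 (within the scatter) and the step of a number 10 percentage points lower from compound 1 to compound 3 (within the scatter) leave compound 3 inseparable from both of the others, even though compound 1 and compound 2 are separated from each other by more than the usual scatter. This shows something the first pair could not: on the carbonyl carbon whose other neighbour is the amide-type nitrogen in a ring, a group attached directly through carbon, 1-fluoro-1-methylethyl, can stand in place of one attached through oxygen without a clear change in the maximal response. Nothing available here explains these numbers or says what lies behind them.

From the compounds shown here alone, what the fluorine contributes stays open, and the plain 1-methylethyl group on the same carbonyl carbon would be the direct comparison with compound 3. Also open, going by these compounds, is how an amine such as dimethylamino or a longer chain such as butyl would read at this place, and whether an oxetan-3-yl group joined directly to the carbonyl carbon would read like compound 2.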